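A few compounds are considered here, and "the series" means these few. Any claim that something is new, unique, unknown or untested is made for them only; others in the source may bear on it.

Three compounds of the series have numbers in a functional assay on HeLa cells (Homo sapiens) for antiproliferative activity, read by MTT assay, with a stated time of 48 h; a higher number here means a weaker inhibitor, a lower number a stronger inhibitor: compound 1 `C=C(c1cc(OC)c(OC)c(OC)c1)c1ccc(OC)c(O)c1NC(C)=O` gives 90 nM, compound 2 `C=C(c1cc(OC)c(OC)c(OC)c1)c1ccc(OC)c(O)c1NC(=O)COC` gives 330 nM and compound 3 `C=C(c1cc(OC)c(OC)c(OC)c1)c1ccc(OC)c(O)c1NC(=O)CN(C)C` gives 120 nM. On these numbers, compound 3 stands close to compound 1 and apart from compound 2. The two measured steps that place it are a 1.3-fold higher number from compound 1 to compound 3 (0.12 log units; within the scatter) and a 2.8-fold lower number from compound 2 to compound 3 (0.44 log units; beyond the scatter).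

Compound 4 `C=C(c1cc(OC)c(OC)c(OC)c1)c1ccc(OC)c(O)c1NC(=O)CO` has hydroxy in place of dimethylamino on a saturated chain carbon bound to a carbonyl carbon. Hydroxy has not been measured at this place, so the evidence is indirect. The nearest comparison is compound 2 at 330 nM, whose methoxy is also attached through oxygen. Among the measured compounds shown here, its step from the unsubstituted chain is a 3.7-fold higher number from compound 1 to compound 2 (0.56 log units; beyond the scatter), and this is the only step in the set that goes clearly upward from compound 1. Hydroxy may not behave like methoxy, so only part of that shift is carried over. In this assay, a small rise in the number is expected, within the scatter, though the upper range reaches the value of compound 2. The estimated step is a 1.7-fold higher number from compound 3 to compound 4 (0.22 log units; within the scatter). For compound 4 the estimated value is 200 nM, with an expected range of 90 nM to 450 nM.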

Compound 4, half-maximal inhibitory concentration: 20 nM
Compound 4: the middle estimate sits 10-fold (1.00 log units) above what was measured, outside the stated range (below it).
By their numbers in this assay, from the lowest: compound 4; then compounds 1 and 3 (each within the scatter of the next); then compound 2.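

The hydroxy group gives the first clear fall from the unsubstituted chain in this assay (a 4.5-fold lower number from compound 1 to compound 4 (0.65 log units; beyond the scatter)), whereas methoxy at this place raised the number and dimethylamino stayed within the scatter of hydrogen. Taking only the methyl off the oxygen produces the largest step among these compounds (a 17-fold lower number from compound 2 to compound 4 (1.22 log units; beyond the scatter)), so the two groups attached through oxygen fall on opposite sides of the unsubstituted chain and methoxy is a poor guide to hydroxy here. The change from dimethylamino is also beyond the scatter (a 6.0-fold lower number from compound 3 to compound 4 (0.78 log units; beyond the scatter)), which shows that a substituent on this saturated chain carbon bound to a carbonyl carbon can move the number in either direction, with hydroxy alone giving a lower number than hydrogen among the groups shown.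

Going by these compounds, it remains open how narrowly the gain depends on hydroxy, which a primary amine, a carboxylic acid or a longer hydroxyethyl chain at the same place would help to define. No measurement shown here explains the difference between hydroxy and methoxy at this position.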